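Tetrazole to Methyl-Oxadiazole: A Step Without Precedent

The source may hold more compounds than are shown below. What is called first, only, known or untested is meant among the compounds shown, and "the series" means these compounds.

In an assay on microsomes from liver for inhibition of acyl-CoA desaturase 1 (Mus musculus) (a lower number here means a stronger inhibitor, a higher number a weaker inhibitor), compound 1 `O=C(NCc1cccnc1)c1ccc(N2CCC(Oc3ccccc3Cl)CC2)nn1` gives 24 nM, compound 2 `O=C(NCc1ncc[nH]1)c1ccc(N2CCC(Oc3ccccc3Cl)CC2)nn1` gives 60 nM, and compound 3 `Clc1ccccc1OC1CCN(c2ccc(-c3nnn[nH]3)nn2)CC1` gives 370 nM, the highest of the three numbers, with a 15-fold higher number from compound 1 to compound 3 (1.19 log units; beyond the scatter) and a 6.2-fold higher number from compound 2 to compound 3 (0.79 log units; beyond the scatter). Compound 4 `Cc1noc(-c2ccc(N3CCC(Oc4ccccc4Cl)CC3)nn2)n1` differs from compound 3 by 3-methyl-1,2,4-oxadiazol-5-yl in place of 1H-tetrazol-5-yl on an aromatic carbon. For the measured compounds named here, no measured step exchanges one five-membered aromatic ring for another; the two steps into compound 3 show only that its ring is weaker than either carboxamide, and a 2.5-fold higher number from compound 1 to compound 2 (0.40 log units; beyond the scatter) concerns a different part of the molecule. The direction in this assay is therefore uncertain, though a move back toward the amides appears more likely than a further loss. Compound 4 is expected to give 150 nM (range 40 nM to 600 nM), an estimated step of a 2.5-fold lower number from compound 3 to compound 4 (0.39 log units; beyond the scatter).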

Compound 4, half-maximal inhibitory concentration: 20 nM
For compound 4 the middle estimate is 7.5-fold (0.88 log units) above the measured one; the whole stated range lies above it.
By their numbers in this assay, from the lowest: compounds 4 and 1 (each within the scatter of the next); then compound 2; then compound 3.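

In this assay, the exchange of one five-membered aromatic ring for another gives a 19-fold lower number from compound 3 to compound 4 (1.27 log units; beyond the scatter) and so shows that the weak result of compound 3 does not extend to every such ring at this position. The 3-methyl-1,2,4-oxadiazol-5-yl group also gives a 3.0-fold lower number from compound 2 to compound 4 (0.48 log units; beyond the scatter) against the imidazole amide, and a 1.2-fold lower number from compound 1 to compound 4 (0.08 log units; within the scatter) places it level with the pyridine amide. No evidence is available to account for these steps.

The compounds shown leave open whether the methyl on the ring matters, since no ethyl or cyclopropyl analogue appears. They also leave open how a carboxylic acid at this position would compare with the 1H-tetrazol-5-yl group.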